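A few compounds are considered here, and "the series" means these few. Any claim that something is new, unique, unknown or untested is made for them only; others in the source may bear on it.

Of the compounds shown here, two have so far been measured in an assay on isolated protein for inhibition of histone deacetylase 11 (Homo sapiens), read by mobility shift assay; on this read-out higher numbers stand for weaker inhibition and lower numbers for stronger inhibition. Compound 1 `O=C(NO)c1ccc(CN(Cc2ccc(F)cc2)S(=O)(=O)c2c(F)c(F)c(F)c(F)c2F)cc1` gives 787 nM in this assay. Compound 2 `O=C(NO)c1ccc(CN(Cc2ccccc2)S(=O)(=O)c2cc(F)c(F)c(F)c2F)cc1` gives 115 nM, the lowest of the two numbers, and compound 1 stands at a higher number beyond the scatter. Compound 3 `O=C(NO)c1ccc(CN(Cc2ccc(F)cc2)S(=O)(=O)c2cc(F)c(F)c(F)c2F)cc1` follows from compound 2 by a single change: fluoro in place of hydrogen on an aromatic carbon. Among the compounds with values here, no measured pair shows this change on its own, so the account expects a step no larger than the scatter, with no settled direction. Compound 3 is therefore estimated at 150 nM, within 60 nM to 400 nM, an expected step of a 1.3-fold higher number from compound 2 to compound 3 (0.12 log units; within the scatter).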

Compound 3, half-maximal inhibitory concentration: > 1000 nM
Compound 3: a limit, no number (the forecaster's own chance of this, stated with the estimate: 2%); at least 6.6-fold (0.82 log units) between middle value and limit.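

Compound 3 carries a limit of the assay and not a number: the limit of > 1000 nM in this assay, at which 1 of the 3 values shown sits. At this position, para to a large group, the change from phenyl to 4-fluorophenyl is not neutral in this assay: the single fluoro gives an at least 8.6-fold higher number from compound 2 to compound 3 (0.93 log units; beyond the scatter). The other step, an at least 1.2-fold higher number from compound 1 to compound 3 (0.10 log units; that floor lies within the scatter), has a floor within the scatter, so it sets no order between those two compounds.

The compounds shown leave open how far the weakening extends, as compound 3 has no number. They also leave open how a chloro, methyl, methoxy or amine group at this place would read.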